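Receptor binding: piperazine substituent changes on a benzothiazole amide

This account rests on a few compounds, and the source may have more. Where it says the series, first, only, none or still open, it means among the compounds named here.

Measured compounds, with their values in an assay on membranes from liver for displacement of a labelled ligand from Sigma intracellular receptor 2 (Rattus norvegicus), read by scintillation counting, with a stated time of 120 min; a lower number here means a stronger inhibitor, a higher number a weaker inhibitor:
compound 2, `Cc1cccc2sc(NC(=O)CCN3CCN(CC4CCCCC4)CC3)nc12`, 519 nM
compound 1, `Cc1cccc2sc(NC(=O)CCN3CCN(CCCN(C)C)CC3)nc12`, > 1000 nM

For compound 1 the value is a limit of this assay, not a number; it is recorded as the limit of > 1000 nM in this assay, at which 1 of the 2 values shown sits. Within the data shown here, compound 2 is thus the only compound with a number in this assay. The measured step is an at least 1.9-fold lower number from compound 1 to compound 2 (0.28 log units; that floor lies within the scatter).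

Compound 3, `Cc1cccc2sc(NC(=O)CCN3CCN(c4ncccn4)CC3)nc12`, is not yet measured. Its change from compound 2 is pyrimidin-2-yl in place of cyclohexylmethyl on an amine nitrogen in a ring. Among the measured compounds shown here, this touches the same ring nitrogen as the measured step from compound 1 to compound 2, which is the only step that bears on it, and that step reached only a floor within the scatter. For the measured compounds named here, no measured compound carries an aromatic group at this position, so the expectation rests on little. Compound 3 is expected to give a number near that of compound 2, perhaps somewhat higher, with a step of a 1.7-fold higher number from compound 2 to compound 3 (0.24 log units; within the scatter), and an estimate of 900 nM in a range from 250 nM to 3500 nM.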

Compound 3, inhibition constant: > 1000 nM
Compound 3 was reported as a limit (the forecaster's own chance of this, stated with the estimate: 35%); at least 1.1-fold (0.04 log units) between middle value and limit.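

In this assay compound 3 gives > 1000 nM, which is a limit and not a number. Replacing cyclohexylmethyl with pyrimidin-2-yl on the amine nitrogen in the ring gives an at least 1.9-fold higher number from compound 2 to compound 3 (0.28 log units; that floor lies within the scatter), so this first aromatic group at the position shows no sign of a stronger inhibitor, though the floor alone does not separate the two compounds. Compound 2 remains the only compound with a number, and the step from compound 1 to compound 3 cannot be read: the limit of > 1000 nM in this assay, at which 2 of the 3 values shown sit.

As far as these compounds go, whether a phenyl or benzyl group at this nitrogen would give a number remains open, and either would help show whether the loss of a number follows the aromatic ring or its two hetero atoms. Also open, from the compounds shown here alone, is how cyclohexyl bound directly to the nitrogen would compare with cyclohexylmethyl.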